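Selenium-bearing acyl group replaces the pentenyl chain on compound 1

The source may report more compounds than this note shows. Statements on the series, on what has been measured and on what is new or still open speak of the compounds shown alone.

Compound 1, `CCC/C=C/C(=O)N(Cc1ccc(OC)c(O)c1)c1cc(OC)c(OC)c(OC)c1`: 70 nM
Compound 2, `COc1ccc(CNc2cc(OC)c(OC)c(OC)c2)cc1Br`: 29400 nM
Compound 3, `C/C=C/C(=O)N(Cc1ccc(OC)c(Br)c1)c1cc(OC)c(OC)c(OC)c1`: 6430 nM

Of the compounds shown here, three sharing the same trimethoxyphenyl-bearing core have been tested in a functional assay on MGC-803 cells (Homo sapiens) for inhibition, read by MTT assay, with a stated time of 48 h; a higher number here means a weaker inhibitor, a lower number a stronger inhibitor. Compound 1 gives the lowest number of the three, with compound 3 next and compound 2 furthest away. For the measured compounds named here, the only single-point step available is a 4.6-fold lower number from compound 2 to compound 3 (0.66 log units; beyond the scatter), showing that placing an unsaturated acyl group on the ring nitrogen helps. Compound 1 and compound 3 differ in two places at once, so their gap cannot be tied to either change alone.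

Compound 4, `COc1ccc(CN(C(=O)C[Se]C#N)c2cc(OC)c(OC)c(OC)c2)cc1O`, keeps the acylated nitrogen of compound 1 but changes the acyl group: a group of 4 heavy atoms (2 carbon, 1 nitrogen, 1 selenium; no ring) in place of a group of 5 heavy atoms (5 carbon; no ring), on a carbonyl carbon. Going by the values given here, no measured step touches this position, so the expectation rests only on the fact that an acyl group on the nitrogen appears beneficial at all. Because compound 1 already sits at 70 nM, some loss is expected when the chain is swapped for an untested group; the estimated step is a 4.3-fold higher number from compound 1 to compound 4 (0.63 log units; beyond the scatter). Compound 4 is therefore expected to give about 300 nM in this assay, within a range of 50 nM to 3000 nM.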

Compound 4, half-maximal inhibitory concentration: 270 nM
The estimate for compound 4 lay 1.1-fold (0.05 log units) above the measured number; measured number inside the range.
By their numbers in this assay, from the lowest: compound 1; then compound 4; then compound 3; then compound 2.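

For the compounds shown here, measured by this assay the exchange of the pent-1-en-1-yl group on the carbonyl carbon for the selenium-bearing group with its nitrile gives a 3.9-fold higher number from compound 1 to compound 4 (0.59 log units; beyond the scatter) and so provides the first direct reading at this position. Going by these compounds alone, the earlier compounds showed only that adding an acyl group to the nitrogen lowers the number, not how much the choice of acyl group matters. Here, a very different group costs only a modest step, so the all-carbon pent-1-en-1-yl chain is not essential, yet no information given explains the loss. This single exchange cannot separate the part played by the selenium from that of the nitrile. A sulfur atom in place of the selenium, or a methyl group in place of the nitrile, would help to tell them apart.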